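The source may hold more compounds than are shown below. What is called first, only, known or untested is meant among the compounds shown, and "the series" means these compounds.

Compound 1 `c1ccc2sc(Oc3ccc4cc(CN5CCCCC5)oc4c3)nc2c1`, 430 nM; compound 2 `c1cnc2nc(Oc3ccc4oc(CN5CCCCC5)cc4c3)sc2c1`, 66 nM; compound 3 `O=C(O)C1CCN(Cc2coc3cc(Oc4nc5ncccc5s4)ccc23)CC1`, 8.3 nM.

All three were measured in an in vitro assay on Sf9 cells for inhibition of leukotriene A-4 hydrolase (Homo sapiens), read by immunoassay, with stated times of 10 min and 30 min (a higher number here means a weaker inhibitor, a lower number a stronger inhibitor), and share one core. Compound 3 gives the lowest number of the three. Compound 2 sits beyond the scatter above it, and compound 1 further beyond still. Going by the values given here, no pair of these three differs in only one place, so no single step between them can be read off; the values can only be set side by side. Compound 4 `CC(=O)NC1CCN(Cc2coc3cc(Oc4nc5ncccc5s4)ccc23)CC1` has not yet been measured. It differs from compound 3 in one place: acetamido in place of carboxy on a saturated ring carbon. Among the compounds with values here, no measured step matches this change, so the expectation rests on what is known: compound 3 carries the carboxy group and gives the lowest number, while compound 2, whose ring carbon carries no group at all, gives 66 nM. The step of a 3.6-fold higher number from compound 3 to compound 4 (0.56 log units; beyond the scatter) is expected to be a moderate weakening, beyond the scatter but short of the gap to compound 2. Compound 4 is accordingly estimated at 30 nM, with a range from 10 nM to 100 nM.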

Compound 4, half-maximal inhibitory concentration: 3.7 nM
Beside the measured number, compound 4's estimate is 8.1-fold (0.91 log units) above it; measured number outside the range, below it.
By their numbers in this assay, from the lowest: compound 4; then compound 3; then compound 2; then compound 1.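

In this assay, placing acetamido instead of carboxy on the saturated ring carbon, three ring bonds from the ring nitrogen, gives a 2.2-fold lower number from compound 3 to compound 4 (0.35 log units; beyond the scatter). This shows that the carboxy group is not needed for a low number at this position, and that the position accepts acetamido with a modest gain rather than a loss. The two groups have the same counts of hydrogen-bond donors and acceptors, yet the step lies beyond the scatter, so those counts alone do not fix the number here, and nothing at hand gives a reason for the step.

From the compounds shown here alone, whether a primary amine, a methyl ester or a longer acyl chain such as propionamido at this ring carbon would take the number lower or higher remains open, so this single pair does not show how far the trend runs. Also open is whether the change from 4-carboxypiperidin-1-yl to 4-acetamidopiperidin-1-yl would give a step of similar size on a different core, since the compounds shown offer only this one pair.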